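Moving the Chlorine on the Pyridyl Amide

This account rests on a few compounds, and the source may have more. Where it says the series, first, only, none or still open, it means among the compounds named here.

Among the measured compounds shown here, compound 2 `Cc1noc(C)c1-c1cnc(N)c(Oc2ccc(C(=O)Nc3cccc(Cl)n3)cc2)n1` stands alone among the numbers: in a functional assay on LoVo cells (Homo sapiens) for inhibition, read by MTT assay, with a stated time of 72 h (a lower number here means a stronger inhibitor, a higher number a weaker inhibitor), compound 2 gives 39300 nM, the only finite value recorded. Compound 1 `Cc1noc(C)c1-c1cnc(N)c(Oc2ccc(C(=O)NC3CC3)cc2)n1` reached only the limit of > 100000 nM in this assay. For the measured compounds named here, the single measured step, an at least 2.5-fold lower number from compound 1 to compound 2 (0.40 log units; beyond the scatter), exchanges the whole amide substituent and is the only step on record. Compound 3 `Cc1noc(C)c1-c1cnc(N)c(Oc2ccc(C(=O)Nc3cc(Cl)ccn3)cc2)n1` differs from compound 2 by 4-chloropyridin-2-yl in place of 6-chloropyridin-2-yl on an amide-type nitrogen. Going by the values given here, no measured step bears directly on a change of this kind, so a step of a 1.0-fold higher number from compound 2 to compound 3 (0.01 log units; within the scatter) is expected, not beyond the scatter. Compound 3 is therefore estimated at 40000 nM, with a range from 12000 nM to 130000 nM.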

Compound 3, half-maximal inhibitory concentration: > 100000 nM
Compound 3 gave a limit, no number; the forecaster's own chance of this, stated with the estimate: 25%; middle value at least 2.5-fold (0.39 log units) away from the limit.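

In this assay, moving the chlorine alone is enough to change the outcome: 4-chloropyridin-2-yl in place of 6-chloropyridin-2-yl gives an at least 2.5-fold higher number from compound 2 to compound 3 (0.40 log units; beyond the scatter), so these two groups, with the same atoms, are not interchangeable on the amide nitrogen. The finite value of compound 2 therefore cannot be credited to a chloropyridyl amide in general. The step from compound 1 to compound 3 cannot be read, and the step to compound 3 is only a bound, since its value is a limit: the limit of > 100000 nM in this assay, at which 2 of the 3 values shown sit.

From the compounds shown here alone, it remains open whether 6-fluoropyridin-2-yl, 6-methylpyridin-2-yl or pyridin-2-yl without chlorine on the amide nitrogen would give a finite value in this assay.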